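This account rests on a few compounds, and the source may have more. Where it says the series, first, only, none or still open, it means among the compounds named here.

Three compounds were measured in a functional assay on the whole organism for inhibition, with Rattus norvegicus as the target, with stated times of 1 h and 3.5 h, at a dose of 100 mg/kg by the oral route; on this read-out lower numbers stand for less inhibition and higher numbers for more inhibition at the one dose given (going by the name of the read-out). Compound 1 `CC(C)(C)C1CCc2nc(N)ncc2C1` gives 41%, and compound 3 `Cc1ncc2c(n1)CCN(C)C2` gives 45%, a value within the scatter of that of compound 1. Compound 2 `Cc1ncc2c(n1)CCC(C(C)(C)C)C2` reaches only a limit of the assay, < 5% (the limit of < 5% in this assay, at which 1 of the 3 values shown sits). Compound 2 and compound 1 differ in one place, (amino in place of methyl on an aromatic carbon), and this change brought a number at least 36 percentage points higher from compound 2 to compound 1 (beyond the scatter). How the core of compound 3 differs from the core of compound 2 is not broken down here. Compound 4 `CN1CCc2nc(N)ncc2C1` carries the same change on the core of compound 3, (amino in place of methyl on an aromatic carbon). Because the same change gave a number at least 36 percentage points higher from compound 2 to compound 1 (beyond the scatter), a rise is expected, though compound 3 already stands at 45%; the expected step is a number 25 percentage points higher from compound 3 to compound 4 (beyond the scatter). Compound 4 is estimated at 70%, between 48% and 90%.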

Compound 4, a percentage reported as inhibition, in the whole organism at one dose (the size of the read-out at that dose, not a potency): < 5%
Compound 4: only a limit was reported; the forecaster's own chance of this, stated with the estimate: 5%; middle value at least 65 percentage points from the limit.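

In this assay, amino in place of methyl on an aromatic carbon brought a number at least 40 percentage points lower from compound 3 to compound 4 (beyond the scatter), so the gain seen on the first core did not carry over to the second: the same change on two cores in this assay, a number at least 36 percentage points higher (beyond the scatter) from compound 2 to compound 1 and a number at least 40 percentage points lower (beyond the scatter) from compound 3 to compound 4, at least 76 percentage points apart, beyond the scatter of two such steps. Compound 4 gives < 5%, which is a limit of the assay and not a number: the limit of < 5% in this assay, at which 2 of the 4 values shown sit. This shows that the outcome of the change depended on the core in these two pairs, but it does not show why, and two pairs set no rule for other cores in the series.

The compounds shown leave open how a methoxy group or a dimethylamino group in the same place would behave on either core. They also leave open whether an ethyl or a benzyl group in place of the methyl on the ring nitrogen of compound 4 would alter the result.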